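Acetoxymethyl in place of a thioester: compound 4 expected

The compounds below may be only part of what the source reports. "The series", "measured", "known", "first", "only" and "open" are said of these compounds alone.

Compound 1 `CCc1cccc2c(OC)c(-c3occ(C)c3C(=S)OC)ccc12` carries a methyl thioester on the five-membered aromatic ring with one oxygen. In a functional assay on A549 cells (Homo sapiens) for cytotoxicity, read by MTT assay, with a stated time of 72 h (on this read-out higher numbers stand for an effect only at larger amounts of compound and lower numbers for an effect already at smaller amounts), compound 1 gives 6.2 ug/mL, the higher of the two numbers measured and beyond the scatter above compound 2 `CCOc1c(-c2occ(C)c2C(=O)OC)ccc2c(CC)cccc12`, which in this assay gives 2.4 ug/mL. Compound 3 `CCOc1c(-c2occ(C)c2CO)ccc2c(CC)cccc12` reaches only a limit in this assay, > 10 ug/mL. Among the compounds with values here, the single step between compounds that differ in one place, an at least 4.1-fold higher number from compound 2 to compound 3 (0.61 log units; beyond the scatter), points to a weaker effect once the methoxycarbonyl becomes a hydroxymethyl; the limit of > 10 ug/mL in this assay, at which 1 of the 3 values shown sits, marks where compound 3 sits.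

Compound 4 `CCc1cccc2c(OC)c(-c3occ(C)c3COC(C)=O)ccc12` differs from compound 1 by a group of 5 heavy atoms (3 carbon, 2 oxygen; no ring) in place of a group of 4 heavy atoms (2 carbon, 1 oxygen, 1 sulfur; no ring), on an aromatic carbon. Within the data shown here, no measured step replaces a thioester by an acetoxymethyl, and compound 1 and compound 2 differ in two places, so only their two values can be set side by side. The step of an at least 4.1-fold higher number from compound 2 to compound 3 (0.61 log units; beyond the scatter) is the nearest guide, and a modest move toward a higher number is expected, a 1.6-fold higher number from compound 1 to compound 4 (0.21 log units; within the scatter). Compound 4 is therefore expected to give about 10 ug/mL in this assay, within 4 ug/mL to 25 ug/mL.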

Compound 4, concentration for half-maximal effect: > 10 ug/mL
Compound 4: only a limit was reported (the forecaster's own chance of this, stated with the estimate: 45%); the middle value lies on the limit itself.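

In this assay compound 4 gives > 10 ug/mL, which is a limit and not a number. Acetoxymethyl in place of the methyl thioester on this aromatic carbon gives an at least 1.6-fold higher number from compound 1 to compound 4 (0.20 log units; that floor lies within the scatter), so the change can be read only as a floor, and that floor does not separate compound 4 from compound 1 beyond the scatter. What is new is that a second group at this position, one counted with no hydrogen-bond donors, now reaches the limit alongside the hydroxymethyl of compound 3: the limit of > 10 ug/mL in this assay, at which 2 of the 4 values shown sit.

On these data alone, whether an amide, a carboxylic acid or an amine on this carbon would give a number under the limit stays open. As far as these compounds go, it also stays open how the thioester and the methoxycarbonyl compare on one shared core, as compound 1 and compound 2 differ in two places.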